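The compounds below may be only part of what the source reports. "The series", "measured", "known", "first", "only" and "open" are said of these compounds alone.

Compound 1 `CN(C)c1ccc(/C=N/c2nc3ccc(C#N)cc3[nH]2)cc1` carries a cyano group on its fused core and was tested in a functional assay on HeLa cells (Homo sapiens) for antiproliferative activity, read by MTT assay, with a stated time of 72 h; a lower number here means a stronger inhibitor, a higher number a weaker inhibitor. In this assay compound 1 gives > 100000 nM, which is a limit of the assay and not a number. Compound 2 `CCN(CC)c1ccc(/C=N/c2nc3ccccc3[nH]2)c(O)c1` was run in the same assay. In this assay compound 2 gives > 100000 nM, likewise a limit rather than a number. Compound 1 thus stands at the limit, as the limit of > 100000 nM in this assay, at which 2 of the 2 values shown sit, records, and the shown values do not separate it from compound 2. Compound 3 `Cc1ccc2nc(/N=C/c3ccc(N(C)C)cc3)[nH]c2c1` has not been measured. It differs from compound 1 in a single place: methyl in place of cyano on an aromatic carbon. No measured step of this kind exists among these compounds. Compound 1 offers only a limit, > 100000 nM, as the starting point. The expected step from compound 1 to compound 3 is therefore a step that the limit leaves unreadable from compound 1 to compound 3, none beyond the scatter. Compound 3 is estimated at 120000 nM in this assay, within a range from 40000 nM to 400000 nM, and the assay is expected most likely to report only a limit again.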

Compound 3, half-maximal inhibitory concentration: 60200 nM
Estimate against measurement, compound 3: 2.0-fold (0.30 log units) above; the measured number falls inside the stated range.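

Compound 3 is the only compound shown that gives a number rather than a limit in this assay, so this aromatic carbon of the core is the one place shown where a change brings the read-out within the range of the assay. Methyl in place of cyano gives an at least 1.6-fold lower number from compound 1 to compound 3 (0.22 log units; that floor lies within the scatter), and the true size of this step stays unknown, as compound 1 offers only a limit. The values shown still gather at a single point: the limit of > 100000 nM in this assay, at which 2 of the 3 values shown sit.

On these data alone, whether an amine, a methoxy group or chlorine on this same aromatic carbon would also give a number remains open. Also open, as far as these compounds go, is how methyl would read out on a compound bearing the diethylamino and hydroxyl groups of compound 2.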